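A few compounds are considered here, and "the series" means these few. Any claim that something is new, unique, unknown or untested is made for them only; others in the source may bear on it.

In an ADME assay on BHK-21 cells (Mesocricetus auratus) for cytotoxicity, with a stated time of 3 days (on this read-out lower numbers stand for higher toxicity in this test and higher numbers for lower toxicity in this test), compound 2, `O=C(CCSc1nnc(-c2ccncc2)s1)Nc1ccccc1`, gives > 50000 nM, which is a limit of the assay.
Compound 3, `CC(CSc1nnc(-c2ccncc2)s1)C(=O)Nc1c(Cl)cccc1Cl`, in this assay gives > 50000 nM, again a limit.
Compound 1, `CC(Sc1nnc(-c2ccncc2)s1)C(=O)NCc1ccc(Cl)cc1`, has no result in this assay: for compound 1 the entry reads "not determined" (no result reported).

Compound 2 thus stands at the limit of > 50000 nM in this assay, at which 2 of the 3 values shown sit, and no single number places it against any neighbour. Compound 4, `O=C(CCSc1nnc(-c2ccncc2)s1)NCc1ccccc1Cl`, differs from it by 2-chlorobenzyl in place of phenyl on an amide-type nitrogen. Going by the values given here, no step between two measured compounds exists in this set, so nothing shows how far such a change moves the read-out. The expectation for compound 4 is a step of a number no higher from compound 2 to compound 4 (the limit leaves the size open), none beyond the scatter, with a limit again the most likely report. Compound 4 is accordingly estimated at 50000 nM, within 20000 nM to 100000 nM.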

Compound 4, half-maximal cytotoxic concentration: > 50000 nM
Compound 4: only a limit was reported (the forecaster's own chance of this, stated with the estimate: 75%); the middle value lies on the limit itself.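

Going by these compounds alone, compound 2 and compound 4 are both reported only as limits in this assay, so no step between them can be read. The compounds shown leave open the concentration at which any of them harms these cells, since none has a single number: the limit of > 50000 nM in this assay, at which 3 of the 4 values shown sit.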